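Ester in place of the morpholinyl hydrazide on the pyrazole carbonyl

The source may report more compounds than this note shows. Statements on the series, on what has been measured and on what is new or still open speak of the compounds shown alone.

Measured compounds:
- compound 1 `COc1cccc(OC)c1C(=O)Nc1c[nH]nc1C(=O)NN1CCOCC1` — > 50000 nM
- compound 2 `CCc1ccccc1C(=O)Nc1c[nH]nc1C(=O)N[C@H]1CC[C@H](OC)CC1` — 3400 nM
- compound 3 `CO[C@H]1CC[C@H](NC(=O)c2n[nH]cc2NC(=O)c2c(C)nc3ccccn23)CC1` — 34000 nM

The three compounds share a core and were tested in an ADME assay on MRC5 cells (Homo sapiens) for inhibition, with a stated time of 72 h; a higher number here means that more compound is needed for the effect, a lower number that less compound is needed. For compound 1 the result is a limit of the assay, not a number: compound 1 gives > 50000 nM, so its effect was not reached within the tested range. Compound 2 gives 3400 nM and compound 3 gives 34000 nM in this assay; these two values are simply what was observed, and no single-point comparison connects them to compound 1 or to each other. Where compound 1 stands is therefore told only by the limit of > 50000 nM in this assay, at which 1 of the 3 values shown sits.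

Compound 4 `COC(=O)c1n[nH]cc1NC(=O)c1c(OC)cccc1OC` is the compound not yet measured. It differs from compound 1 by methoxy in place of (morpholin-4-yl)amino on a carbonyl carbon. Because compound 1 sits at the limit of > 50000 nM in this assay, at which 1 of the 3 values shown sits, the step from compound 1 to compound 4 in this assay can only be a limit-anchored guess. Compound 4 is expected to land at roughly 35000 nM, within about 8000 nM to 150000 nM, the estimated step being an at least 1.4-fold lower number from compound 1 to compound 4 (0.15 log units; that floor lies within the scatter).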

Compound 4, half-maximal effective concentration: > 50000 nM
Compound 4 was reported as a limit; the forecaster's own chance of this, stated with the estimate: 50%; middle value at least 1.4-fold (0.15 log units) away from the limit.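

In this assay, for the compounds shown here, compound 4, like compound 1, is reported only as a limit, so no step from compound 1 to compound 4 can be read. The compounds shown leave open whether methoxy in place of (morpholin-4-yl)amino on a carbonyl carbon changes the half-maximal effective concentration at all.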